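Replacing a Hydroxyphenyl by a Fluorophenyl: Expected Cytotoxicity

This account rests on a few compounds, and the source may have more. Where it says the series, first, only, none or still open, it means among the compounds named here.

Measured compounds:
compound 1 `O=C(COc1cccc2ccccc12)N/N=C/c1cccc([N+](=O)[O-])c1`: 12.1 ug/mL
compound 2 `O=C(COc1cccc2ccccc12)N/N=C/c1cccc(O)c1`: 32.6 ug/mL
compound 3 `COc1ccc(/C=N/NC(=O)COc2cccc3ccccc23)cc1O`: 7.05 ug/mL

In an ADME assay on MT4 cells (Homo sapiens) for cytotoxicity, read by MTT assay, with a stated time of 4 days (on this read-out higher numbers stand for lower toxicity in this test and lower numbers for higher toxicity in this test), compound 2 stands highest of the three numbers. There is a 2.7-fold higher number from compound 1 to compound 2 (0.43 log units; beyond the scatter), and there is a 4.6-fold lower number from compound 2 to compound 3 (0.67 log units; beyond the scatter); both steps lie beyond the scatter and both are modest in size.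

Compound 4 `O=C(COc1cccc2ccccc12)N/N=C/c1ccc(F)cc1` has not yet been measured. It differs from compound 2 in one place: 4-fluorophenyl in place of 3-hydroxyphenyl on a carbon with a double bond to nitrogen. Both measured steps also alter the ring on the carbon with a double bond to nitrogen, and in each case the ring of compound 2 gave the higher number while the other ring gave the lower one. The change to compound 4 again removes the hydroxy-bearing ring, so a modest step downward, beyond the scatter, is the expectation here, though the 4-fluorophenyl ring itself has no measured precedent among these compounds.

Compound 4 is therefore estimated at 15 ug/mL in this assay, with a range from 6 ug/mL to 35 ug/mL. This estimate means a 2.2-fold lower number from compound 2 to compound 4 (0.34 log units; beyond the scatter) is expected.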

Compound 4, half-maximal cytotoxic concentration: 65.1 ug/mL
Compound 4: the middle estimate sits 4.3-fold (0.64 log units) below what was measured; measured number outside the range, above it.
By their numbers in this assay, from the lowest: compounds 3 and 1 (each within the scatter of the next); then compounds 2 and 4 (each within the scatter of the next).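

In this assay, putting 4-fluorophenyl in place of 3-hydroxyphenyl on this carbon gives a 2.0-fold higher number from compound 2 to compound 4 (0.30 log units; within the scatter), so the two rings cannot be told apart in this test. The earlier steps shown here from compound 2 to compound 1 and to compound 3 both ended in lower numbers beyond the scatter, whereas this result shows that not every change of ring at this place does so, and that the hydroxy group is not required to keep the number at the level of compound 2. No measurement on hand explains why this change differs from those two.

Compound 4 changes both the group on the ring and where it sits, and the compounds shown do not separate these two changes. From the compounds shown here alone, how the ring would behave carrying an amine or a carboxylic acid also remains open.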